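Turning the ring stereocentre of compound 3

The source may hold more compounds than are shown below. What is called first, only, known or untested is meant among the compounds shown, and "the series" means these compounds.

Compound 1, `NS(=O)(=O)c1ccc(COc2ccc(CNC(=O)[C@@H]3CCC(=O)N3Cc3ccc(F)cc3)cc2)cc1`, in an assay on HEK293 cells for inhibition of Ataxin-2 (Mus musculus), read by fluorescence and Amplex Red (a higher number here means a weaker inhibitor, a lower number a stronger inhibitor), gives a value that is a limit of the assay, > 5000 nM.
Compound 2, `O=C(O)c1ccc(COc2ccc(CNC(=O)[C@@H]3CCCN3Cc3ccccc3)cc2)cc1`, gives a limit as well, > 5000 nM.
Compound 3, `O=C(O)c1ccc(COc2ccc(CNC(=O)[C@@H]3CCCN3Cc3ccc(F)cc3)cc2)cc1`, gives 800 nM.

For the measured compounds named here, compound 3 therefore holds the only numerical value shown in this assay; the other two compounds sit at the limit of > 5000 nM in this assay, at which 2 of the 3 values shown sit. Going by the values given here, the single measured step, an at least 6.2-fold lower number from compound 2 to compound 3 (0.79 log units; beyond the scatter), shows that adding a fluoro in place of hydrogen on an aromatic carbon moved the number clearly, from a limit to a measured value.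

Compound 4, `O=C(O)c1ccc(COc2ccc(CNC(=O)[C@H]3CCCN3Cc3ccc(F)cc3)cc2)cc1`, differs from compound 3 as follows: the two compounds have the same atoms and bonds and differ only in configuration as drawn: 1 of 1 stereo elements differ; a stereocentre at a saturated ring carbon is drawn S in compound 3 and R in compound 4. Among the compounds with values here, no measured step in this set changes configuration; the only measured step concerns a fluoro substituent and so does not bear on a mirror-image change. The data give no guide to the size or direction of the effect, and either a number like that of compound 3 or a weaker one is possible. Weighing both possibilities, the expected step is a 2.5-fold higher number from compound 3 to compound 4 (0.40 log units; beyond the scatter), toward a somewhat higher number. Compound 4 is therefore estimated at 2000 nM, with a plausible range from 500 nM to 8000 nM.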

Compound 4, half-maximal inhibitory concentration: > 5000 nM
Compound 4 was reported as a limit (the forecaster's own chance of this, stated with the estimate: 35%); middle value at least 2.5-fold (0.39 log units) away from the limit.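

The configuration at this saturated ring carbon counts in this assay: redrawing it from S to R, with no atom or bond altered, gives an at least 6.2-fold higher number from compound 3 to compound 4 (0.79 log units; beyond the scatter). The earlier step concerned a fluoro in place of hydrogen on an aromatic carbon, whereas this pair isolates the three-dimensional arrangement at one centre, and the change in the number can be tied to that centre alone because nothing else separates the two compounds: the fact that compounds 3 and 4 differ only in the configuration as drawn. For the compounds shown here, compound 4 ends at a limit of the assay rather than at a number, so the only measurable value in this set remains tied to one configuration, with one fluoro-bearing ring and one carboxylic acid: the limit of > 5000 nM in this assay, at which 3 of the 4 values shown sit.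

The compounds shown leave open how much weaker compound 4 really is, as a limit gives only one side of the step. They also leave open whether the S drawing would still give the lower number with another group in place of the fluoro, such as chloro or methoxy, or with an amine in place of the carboxylic acid.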